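The compounds below may be only part of what the source reports. "The series", "measured", "known", "first", "only" and "open" are said of these compounds alone.

In an ADME assay on HepG2 2.2.15 cells (Homo sapiens) for cytotoxicity, read by MTT assay, with stated times of 48 h and 9 days (on this read-out higher numbers stand for lower toxicity in this test and lower numbers for higher toxicity in this test), compound 1 `COc1ccc2c(=O)c(/C=C/C(=O)NCc3cccc(F)c3)coc2c1` gives 475000 nM, and compound 2 `COc1ccc2c(=O)c(/C=C/C(=O)NCc3ccc(C)cc3)coc2c1` gives 257000 nM. Within the data shown here, of these two numbers compound 2 holds the lower one, though the single step of a 1.8-fold lower number from compound 1 to compound 2 (0.27 log units; within the scatter) lies within the scatter. Compound 3 `COc1ccc2c(=O)c(/C=C/C(=O)Nc3ccc(F)cc3)coc2c1` arises from compound 2 by 4-fluorophenyl in place of 4-methylbenzyl on an amide-type nitrogen. No measured step alters the group on the amide-type nitrogen in this way; the one step shown, a 1.8-fold lower number from compound 1 to compound 2 (0.27 log units; within the scatter), exchanged the aromatic group and did not move the number beyond the scatter. The step of a 1.2-fold higher number from compound 2 to compound 3 (0.07 log units; within the scatter) is therefore expected to stay within the scatter. Compound 3 is estimated at 300000 nM, between 120000 nM and 800000 nM.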

Compound 3, half-maximal cytotoxic concentration: 743000 nM
Compound 3: middle estimate off by 2.5-fold (0.39 log units), on the low side; the range from low to high includes it.
By their numbers in this assay, from the lowest: compounds 2, 1 and 3 (each within the scatter of the next, the first and the last beyond it).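

In this assay, among these compounds, a change to the group on the amide-type nitrogen moves the number past the scatter for the first time, giving a 2.9-fold higher number from compound 2 to compound 3 (0.46 log units; beyond the scatter) as 4-methylbenzyl leaves. The same entering group gives only a 1.6-fold higher number from compound 1 to compound 3 (0.19 log units; within the scatter) when 3-fluorobenzyl leaves, so 4-fluorophenyl does not bring one fixed step across these compounds. Nothing measured here explains this difference. Going by these compounds, how a longer chain on the amide-type nitrogen, or an amine in place of 4-fluorophenyl, would read in this test remains open.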